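Chain shortening from compound 2 to compound 3

The compounds below may be only part of what the source reports. "The series", "measured", "known", "first", "only" and "open" are said of these compounds alone.

For the measured compounds named here, in a functional assay on NCI-H460 cells (Homo sapiens) for cytotoxicity (a higher number here means a weaker inhibitor, a lower number a stronger inhibitor), compound 2 (`CS(=O)(=O)c1ccc2nc(NC(=O)CCCCCCC(=O)NO)sc2c1`) gives 6.54 ug/mL, the lowest of the two numbers so far. In this assay, compound 1 (`COc1ccc2nc(NC(=O)CCCCC(=O)NO)sc2c1`) gives 21.4 ug/mL. The gap between these two compounds lies beyond the scatter. Compound 3 (`CS(=O)(=O)c1ccc2nc(NC(=O)CCCCC(=O)NO)sc2c1`) remains unmeasured. Its change from compound 2 is hydroxycarbamoyl in place of 2-(hydroxycarbamoyl)ethyl on a saturated chain carbon, four bonds along the chain from a carbonyl carbon, with hydroxycarbamoyl in place of 2-(hydroxycarbamoyl)ethyl on a saturated chain carbon, four bonds along the chain from a carbonyl carbon. Going by the values given here, no measured pair isolates this change. A move toward a weaker inhibitor is expected in this assay, with an estimated step of a 2.1-fold higher number from compound 2 to compound 3 (0.33 log units; beyond the scatter). The expected value for compound 3 is 14 ug/mL, within an estimated range of 5 ug/mL to 35 ug/mL.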

Compound 3, half-maximal inhibitory concentration: > 30 ug/mL
Compound 3: only a limit was reported (the forecaster's own chance of this, stated with the estimate: 3%); middle value at least 2.1-fold (0.33 log units) away from the limit.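

In this assay, for the compounds shown here, shortening the chain on the methylsulfonyl compound weakens inhibition: hydroxycarbamoyl in place of 2-(hydroxycarbamoyl)ethyl gives an at least 4.5-fold higher number from compound 2 to compound 3 (0.66 log units; beyond the scatter), the first measured pair to isolate chain length at this position. Methylsulfonyl in place of methoxy on an aromatic carbon gives an at least 1.4-fold higher number from compound 1 to compound 3 (0.14 log units; that floor lies within the scatter), so no order of these two groups can be read at this chain length. Compound 3 stands only as a limit: the limit of > 30 ug/mL in this assay, at which 1 of the 3 values shown sits.

Still open, going by these compounds, is whether a chain longer than that of compound 2 lowers the number further. Also open, on these data alone, is whether the methoxy compounds respond to chain length in the same way.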